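Cytotoxicity notes on a bicyclic thymidine series

A few compounds are considered here, and "the series" means these few. Any claim that something is new, unique, unknown or untested is made for them only; others in the source may bear on it.

Going by the values given here, compound 1 `Cc1cn([C@@H]2O[C@H](CO[Si](C)(C)C(C)(C)C)[C@@]3(OS(=O)(=O)C=C3NC(N)=O)[C@H]2O[Si](C)(C)C(C)(C)C)c(=O)n(C)c1=O` is the most toxic of the three measured members in a functional assay on MT4 cells (Homo sapiens) (on this read-out lower numbers stand for higher toxicity in this test and higher numbers for lower toxicity in this test), where compound 1 gives 3700 nM. Compound 2 `Cc1cn([C@@H]2O[C@@H]3COC4(O)CS(=O)(=O)O[C@@]34[C@H]2O)c(=O)[nH]c1=O` gives 100000 nM in this assay, and compound 3 `Cc1cn([C@@H]2O[C@@H]3COC4(O)CS(=O)(=O)O[C@@]34[C@H]2O[Si](C)(C)C(C)(C)C)c(=O)[nH]c1=O` gives 100000 nM; the step of no change at the digits printed from compound 2 to compound 3 (within the scatter) shows that attaching a group of 7 heavy atoms to an oxygen on a saturated carbon leaves the read-out unchanged. Compound 1 therefore stands well below both of the other measured compounds, beyond the scatter in each case.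

Compound 4 `Cc1cn([C@@H]2O[C@H](CO[Si](C)(C)C(C)(C)C)[C@@]3(OS(=O)(=O)C=C3NCCC(=O)OCc3ccccc3)[C@H]2O[Si](C)(C)C(C)(C)C)c(=O)n(C)c1=O` differs from compound 1 by 2-(benzyloxycarbonyl)ethyl in place of carbamoyl on an amine nitrogen. Among the compounds with values here, no measured step touches the amine nitrogen on the double-bonded ring carbon, so nothing directly comparable exists; the only step in hand, from compound 2 to compound 3, concerns a different place and a different core and was flat. In the absence of a relevant precedent, the expected step of a 1.1-fold lower number from compound 1 to compound 4 (0.02 log units; within the scatter) is none beyond the scatter, in no particular direction. On that basis compound 4 is estimated to give 3500 nM in this assay, with a range from 900 nM to 14000 nM covering the uncertainty of an untested change at an untested position.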

Compound 4, half-maximal cytotoxic concentration: > 250000 nM
Compound 4 ended at the assay's limit (the forecaster's own chance of this, stated with the estimate: 10%); middle value at least 71-fold (1.85 log units) from the limit.
By their numbers in this assay, from the lowest: compound 1; then compounds 2 and 3 (each within the scatter of the next). At a limit, above all of these: compound 4.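

Going by these compounds alone, replacing carbamoyl with 2-(benzyloxycarbonyl)ethyl on the amine nitrogen gives an at least 67-fold higher number from compound 1 to compound 4 (1.82 log units; beyond the scatter) in this assay, whereas the only earlier step, on an oxygen on a saturated carbon and on a different core, showed no change at the digits printed from compound 2 to compound 3 (within the scatter). This nitrogen is therefore the first place in the series where a single change is seen to move the read-out, and on the core of compound 1 the toxicity in this test depends on the group it carries. The value of compound 4, > 250000 nM, is a limit of the assay and not a number, so the step fixes only a minimum size: the limit of > 250000 nM in this assay, at which 1 of the 4 values shown sits.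

The compounds shown leave open which part of 2-(benzyloxycarbonyl)ethyl goes with the change, since the chain, the ester and the phenyl ring enter together; a plain ethyl group, or the free carboxylic acid on the same chain, would separate these parts. Also open, from the compounds shown here alone, is whether a bare amine on this nitrogen stays close to compound 1, or whether carbamoyl itself is needed for the toxicity seen in this test.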